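Swapping methyl for dimethylamino in compound 4

The source may report more compounds than this note shows. Statements on the series, on what has been measured and on what is new or still open speak of the compounds shown alone.

Measured in an ADME assay on HEK293 cells (Homo sapiens) for cytotoxicity, with a stated time of 72 h; on this read-out lower numbers stand for an effect already at smaller amounts and higher numbers for an effect only at larger amounts of compound:
- compound 1 `Cc1cc(NC(=O)Nc2ccc(C(C)(C)C)cc2)c2ccccc2n1`: > 25000 nM (a limit)
- compound 2 `CCc1ccc(NC(=O)Nc2cc(C)nc3ccccc23)cc1`: 16000 nM
- compound 3 `Cc1ccc(NC(=O)Nc2cc(C)nc3ccccc23)cc1`: > 25000 nM (a limit)

Compound 3 stands at > 25000 nM, which is a limit and not a number. Within the data shown here, compound 2 gives the only true number, 16000 nM. The rest of the picture rests on the limit of > 25000 nM in this assay, at which 2 of the 3 values shown sit (a limit shared by two compounds).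

Compound 4 `Cc1cc(NC(=O)Nc2ccc(N(C)C)cc2)c2ccccc2n1` has not been measured yet. In it, dimethylamino takes the place of methyl on an aromatic carbon, para to a large group (dimethylamino in place of methyl on an aromatic carbon).

The measured steps that bear on this also change the group at that place. The data show an at least 1.5-fold lower number from compound 1 to compound 2 (0.19 log units; that floor lies within the scatter) and an at least 1.5-fold higher number from compound 2 to compound 3 (0.19 log units; that floor lies within the scatter) as the two steps with a readable floor, while the third is a step that the two limits leave unreadable from compound 1 to compound 3 and tells nothing. Among the measured compounds shown here, neither floor goes beyond the scatter, and no measured step covers dimethylamino itself.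

The step expected is an at least 1.1-fold lower number from compound 3 to compound 4 (0.05 log units; that floor lies within the scatter) and it should stay small, with any move going toward lower numbers in this assay, as compound 2 at 16000 nM hints. Compound 4 is estimated at 22000 nM (10000 nM to 50000 nM).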

Compound 4, half-maximal effective concentration: > 25000 nM
Compound 4 was reported as a limit (the forecaster's own chance of this, stated with the estimate: 60%); middle value at least 1.1-fold (0.05 log units) away from the limit.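

In this assay compound 4 gives > 25000 nM, which is a limit and not a number. Dimethylamino brings nitrogen and a hydrogen-bond acceptor to a place that has so far held only carbon groups, yet the one readable step is an at least 1.5-fold higher number from compound 2 to compound 4 (0.19 log units; that floor lies within the scatter), and its floor does not go beyond the usual scatter, while the steps from compound 3 and from compound 1 cannot be read because both ends are limits. The new group therefore adds no readable change at this place, and ethyl in compound 2 remains the only group shown with a true number, so the comparison still rests mainly on one shared limit: the limit of > 25000 nM in this assay, at which 3 of the 4 values shown sit.

On these data alone, how far compound 1, compound 3 and compound 4 lie beyond that limit stays open, so any real differences among methyl, tert-butyl and dimethylamino remain hidden. Also open, as far as these compounds go, is whether the true number seen with ethyl would recur with a longer chain such as propyl, or how a carboxylic acid or a methoxy group at this place would read in this assay.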